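One Chloro Fewer: From Compound 2 to Compound 4

A few compounds are considered here, and "the series" means these few. Any claim that something is new, unique, unknown or untested is made for them only; others in the source may bear on it.

Compound 1 `COc1cc(OCc2cnc(Cl)c(Cl)c2)ccc1CNCc1ccncc1` gives 400 nM in a functional assay on HeLa cells (Homo sapiens) for inhibition, with a stated time of 72 h; on this read-out lower numbers stand for an effect already at smaller amounts and higher numbers for an effect only at larger amounts of compound.
Compound 2 `COc1cc(CNCc2ccncc2)ccc1OCc1cnc(Cl)c(Cl)c1` gives 220 nM.
Compound 3 `Clc1ccc(COc2ccc(CNCc3ccncc3)cc2)cc1` gives 4000 nM.

Among these three numbers, compound 2 stands lowest. Its nearest neighbour is compound 1, whose number lies higher by an amount within the scatter of this assay, so the two cannot be ordered against each other. Compound 3 stands furthest away, with a number beyond the scatter, so of that pair compound 3 is the weaker on this read-out. Among the compounds with values here, no two of the measured compounds differ in only one place, so no single step is known from the data themselves.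

Compound 4 `COc1cc(CNCc2ccncc2)ccc1OCc1ccc(Cl)nc1` has not been measured. It differs from compound 2 in one place: hydrogen in place of chloro on an aromatic carbon. Nothing measured isolates this substitution; the gap between compound 2 and compound 3 mixes several changes and cannot stand in for it. The author therefore expects for compound 4 a moderate loss rather than a gain, a step of a 2.3-fold higher number from compound 2 to compound 4 (0.36 log units; beyond the scatter) in this assay, with wide uncertainty around that guess. Compound 4 is thus estimated at 500 nM, with a range from 180 nM to 1500 nM.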

Compound 4, half-maximal effective concentration: 400 nM
The estimate for compound 4 lay 1.3-fold (0.10 log units) above the measured number, and the stated range covers the measured number.
By their numbers in this assay, from the lowest: compounds 2, 1 and 4 (each within the scatter of the next); then compound 3.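

Within the data shown here, replacing the chloro with hydrogen turns the 5,6-dichloropyridin-3-yl group into 6-chloropyridin-3-yl, and this is the first change that can be read on its own. In this assay, it gives a 1.8-fold higher number from compound 2 to compound 4 (0.26 log units; within the scatter) and so cannot be told apart from repeated measurement of one compound. This chloro, ortho to a chloro group and two atoms from the ring nitrogen, can therefore be exchanged for hydrogen on this core with no difference that this read-out can resolve, and nothing available explains the result in terms of a measured property.

What the compounds shown leave open is how a bromo, a nitrile or an amine would read at this same place, and whether the remaining chloro could also give way to hydrogen. They also leave open whether the same exchange would read alike on the core of compound 1.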